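The source may hold more compounds than are shown below. What is called first, only, known or untested is meant among the compounds shown, and "the series" means these compounds.

Values in an assay on isolated protein for inhibition of aldehyde dehydrogenase 1A1 (Homo sapiens), read by spectrophotometry, tested at 10 uM; a higher number here means more inhibition at the concentration tested (going by the name of the read-out), a lower number less inhibition:
compound 1, `Cc1cccc(Cn2c(CN3CCN(C(=O)C4CCCC4)CC3)nc3ccccc32)c1`: 67.5%
compound 2, `Cc1cccc(Cn2c(CN3CCN(C(=O)c4ccc(C#N)cc4)CC3)nc3ccccc32)c1`: 20.8%

Compound 2 holds the lower of the two numbers in this assay. Among the compounds with values here, its nearest neighbour is compound 1, and the only step in the set, a number 46.7 percentage points lower from compound 1 to compound 2 (beyond the scatter), separates them. Compound 3, `Cc1cccc(Cn2c(CN3CCN(C(=O)C4CCCCC4)CC3)nc3ccccc32)c1`, has not been measured. It differs from compound 2 in one place: cyclohexyl in place of 4-cyanophenyl on a carbonyl carbon. The step from compound 1 to compound 2 bears on this directly, since it ran at the same place in the opposite direction, putting 4-cyanophenyl in place of cyclopentyl on a carbonyl carbon with a large fall. Cyclohexyl is not cyclopentyl, so the reversal cannot be taken as exact, and nothing in the set shows a six-membered non-aromatic ring of carbon only at this position. Still, a rise of broadly the same size is expected in this assay, not a change within the scatter. Compound 3 is therefore expected at 60%, with a range of 35% to 85%, meaning an estimated step of a number 39.2 percentage points higher from compound 2 to compound 3 (beyond the scatter).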

Compound 3, a percentage reported as inhibition, at one concentration (the size of the read-out at that concentration, not a potency): 31.9%
Beside the measured number, compound 3's estimate is 28.1 percentage points above it; measured number outside the range, below it.
By their numbers in this assay, from the lowest: compound 2; then compound 3; then compound 1.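

In this assay the result gives a number 11.1 percentage points higher from compound 2 to compound 3 (beyond the scatter) and shows that replacing 4-cyanophenyl with a non-aromatic ring on this carbonyl carbon does not by itself recover the high number of compound 1. The change of ring among the non-aromatic carbon groups gives a number 35.6 percentage points lower from compound 1 to compound 3 (beyond the scatter) and is a large step, whereas the change from 4-cyanophenyl to cyclohexyl is a modest one, so across these three compounds the split at this position does not follow simply from aromatic against non-aromatic. Nothing available explains why cyclopentyl and cyclohexyl part so far at this position.

Compounds 1, 2 and 3 leave open whether the high number is particular to cyclopentyl or would also hold for cyclobutyl or for an open chain such as isopropyl on the same carbonyl carbon. They also leave open whether the low number of compound 2 belongs to the aromatic ring itself or to its nitrile, which an unsubstituted phenyl group would separate.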